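The source may hold more compounds than are shown below. What is called first, only, known or untested is meant among the compounds shown, and "the series" means these compounds.

Three compounds share one core and differ in the group on the aromatic carbon of that core. Compound 1 `Cc1cc(NCc2ncccn2)n2nc(C)c(-c3ccccc3)c2n1` gives 37900 nM in a physicochemical assay for solubility, read by HPLC, using the shake flask method, measured as kinetic solubility, with a stated time of 2 h, at pH 7.4; a lower number here means a less soluble compound, a higher number a more soluble compound. Compound 2 `Cc1cc(OCc2ccccn2)n2nc(C)c(-c3ccccc3)c2n1` gives 25600 nM in this assay, and a 1.5-fold lower number from compound 1 to compound 2 (0.17 log units; within the scatter). Compound 3 `Cc1cc(NCc2cccs2)n2nc(C)c(-c3ccccc3)c2n1` is known in this assay through a limit, < 5000 nM, and not through a number. Measured against the other two, an at least 7.5-fold lower number from compound 1 to compound 3 (0.87 log units; beyond the scatter) and an at least 5.1-fold lower number from compound 2 to compound 3 (0.70 log units; beyond the scatter), so compound 3 stands lowest of the three, with the limit of < 5000 nM in this assay, at which 1 of the 3 values shown sits, setting how far down it is known.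

Compound 4 `Cc1cc(NCc2nccs2)n2nc(C)c(-c3ccccc3)c2n1` has not yet been measured. It differs from compound 3 in one place: 1,3-thiazol-2-yl in place of thiophen-2-yl on a saturated chain carbon bound to a nitrogen on an aromatic ring. Among the compounds with values here, the step that bears most directly on this change is the one from the pyrimidin-2-yl compound, an at least 7.5-fold lower number from compound 1 to compound 3 (0.87 log units; beyond the scatter), in which the loss of ring nitrogen acceptors came with a drop into the limit; compound 4 puts back one such acceptor, not two. The expectation is therefore a rise in this assay of modest size, an at least 1.8-fold higher number from compound 3 to compound 4 (0.25 log units; that floor lies within the scatter), short of the number compound 1 shows. Compound 4 is estimated at 9000 nM, with a range from 3000 nM to 27000 nM, and a real chance that this assay again reports a limit.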

Compound 4, solubility: 108000 nM
For compound 4 the middle estimate is 12-fold (1.08 log units) below the measured one; the measured number lies above the stated range.
By their numbers in this assay, from the lowest: compounds 2 and 1 (each within the scatter of the next); then compound 4. At a limit, below all of these: compound 3.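

At this place, on a saturated chain carbon bound to a nitrogen on an aromatic ring, the earlier compounds had shown only a fall on leaving pyrimidin-2-yl, and the exchange of thiophen-2-yl for 1,3-thiazol-2-yl now shows a large change in the other direction in this assay, with an at least 21-fold higher number from compound 3 to compound 4 (1.33 log units; beyond the scatter). In this assay compound 3 has a limit and not a number, so the size of that step is only a floor: the limit of < 5000 nM in this assay, at which 1 of the 4 values shown sits. The 1,3-thiazol-2-yl group also carries the series past both earlier measured compounds, with a 2.8-fold higher number from compound 1 to compound 4 (0.45 log units; beyond the scatter) for the exchange at the same place and a 4.2-fold higher number from compound 2 to compound 4 (0.63 log units; beyond the scatter) for the exchange of the whole group on the aromatic carbon, so among these compounds the order does not simply follow the number of ring nitrogens.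

The compounds shown leave open how far compound 3 lies under its limit, and so the true size of the step to compound 4. They also leave open whether the same rise would appear with a (1,3-thiazol-2-yl)methoxy group, or whether a 1,3-thiazol-4-yl or 1,3-oxazol-2-yl ring at this place would behave like 1,3-thiazol-2-yl.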